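The source may report more compounds than this note shows. Statements on the series, on what has been measured and on what is new or still open speak of the compounds shown alone.

Measured compounds:
- compound 1 `CCNC(=O)CCCOc1ccc(-c2nc3ncccn3c2NC2CCCCC2)cc1`; in a toxicity assay on A549 cells (Homo sapiens) for cytotoxicity, read by luminescence and CellTiter-Glo, with a stated time of 48 h (a lower number here means that less compound is tolerated, a higher number that more compound is tolerated), compound 1 gives > 100000 nM, which is a limit of the assay and not a number.
- compound 2 `COCCCCOc1ccc(-c2nc3ncccn3c2NC2CCCCC2)cc1`; in this assay compound 2 gives 100000 nM.

Going by the values given here, compound 2 holds the only number in this assay; the one further value, from compound 1, is a limit. Among the compounds with values here, the one measured step, a number no higher from compound 1 to compound 2 (the limit leaves the size open), has no readable size, as the limit of > 100000 nM in this assay, at which 1 of the 2 values shown sits, sets the starting point.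

Compound 3 `Fc1ccc(COc2ccc(-c3nc4ncccn4c3NC3CCCCC3)cc2)cc1` is not yet measured in this assay. It differs from compound 2 by 4-fluorophenyl in place of 3-methoxypropyl on a saturated chain carbon bound to an oxygen on an aromatic ring. Within the data shown here, no measured step bears directly on this change; the only step, a number no higher from compound 1 to compound 2 (the limit leaves the size open), concerns a different position of the chain and gives no size to lean on. With nothing beyond a pair of values that sit together, the expectation for the step from compound 2 to compound 3 is none beyond the scatter, that is a 1.4-fold lower number from compound 2 to compound 3 (0.15 log units; within the scatter), with a real chance that compound 3 too comes back as a limit.

For compound 3 in this assay the estimate is 70000 nM, expected to lie between 25000 nM and 200000 nM.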

Compound 3, half-maximal cytotoxic concentration: 24000 nM
Beside the measured number, compound 3's estimate is 2.9-fold (0.46 log units) above it; measured number below the stated range.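

The series now has in a 4.2-fold lower number from compound 2 to compound 3 (0.62 log units; beyond the scatter) a step of readable size, so the saturated chain carbon bound to an oxygen on an aromatic ring is a place where a change can move the number in this assay beyond the scatter. The change brings in 4-fluorophenyl, a six-membered aromatic ring of carbon only, where 3-methoxypropyl has no ring, and the comparison with the amide chain of compound 1 points the same way in an at least 4.1-fold lower number from compound 1 to compound 3 (0.61 log units; beyond the scatter). Compound 1 stands at a limit of the assay and not at a number, which leaves only a minimum for the size of that second step: the limit of > 100000 nM in this assay, at which 1 of the 3 values shown sits.

On these data alone, whether the lower number belongs to the aromatic ring as such or to its fluorine stays open; a plain benzyl group or a 4-chlorobenzyl group on the same oxygen would separate the two. Also open, as far as these compounds go, is how the number responds to a chain ending in an amine or a carboxylic acid, and whether the lower number of compound 3 goes with any change in activity outside this cell assay.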